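Exchanging Ethyl for a Trifluoropropylamino Group on Compound 2

The source may report more compounds than this note shows. Statements on the series, on what has been measured and on what is new or still open speak of the compounds shown alone.

Among the measured compounds shown here, in an assay on cells for inhibition of cytochrome P450 11B2, mitochondrial (Homo sapiens), read by HPLC, with a stated time of 90 min (on this read-out lower numbers stand for stronger inhibition and higher numbers for weaker inhibition), compound 2 `CCc1ncncc1-c1nc2cc(F)c(F)cc2n1C1CC1` gives 8 nM, the lower of the two numbers measured so far. Compound 1 `Fc1ccc2nc(-n3ccnn3)n(C3CC3)c2c1` gives 1060 nM in this assay, a gap well beyond the usual scatter. Compound 3 `Fc1cc2nc(-c3cncnc3NCCC(F)(F)F)n(C3CC3)c2cc1F` differs from compound 2 by (3,3,3-trifluoropropyl)amino in place of ethyl on an aromatic carbon. For the measured compounds named here, no measured pair shows this kind of exchange, so its effect cannot be read from the data. The step from compound 2 to compound 3 is expected to be small, a 1.9-fold higher number from compound 2 to compound 3 (0.27 log units; within the scatter), within or near the scatter. Compound 3 is accordingly estimated at 15 nM, with a range from 4 nM to 60 nM.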

Compound 3, half-maximal inhibitory concentration: 3 nM
Compound 3: middle estimate off by 5.0-fold (0.70 log units), on the high side, outside the stated range (below it).
By their numbers in this assay, from the lowest: compound 3; then compound 2; then compound 1.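

In this assay the exchange of ethyl for (3,3,3-trifluoropropyl)amino gives a 2.7-fold lower number from compound 2 to compound 3 (0.43 log units; beyond the scatter) and so shows that this aromatic carbon next to the ring nitrogen accepts a larger chain carrying a hydrogen-bond donor without any loss of inhibition. The exchange brings in the nitrogen, the longer chain and the fluorines together, so this one step cannot assign the gain to any of them. Nothing available explains the gain. Going by these compounds, whether the nitrogen alone suffices stays open, since a plain propylamino chain would separate it from the fluorines. On these data alone, how a longer chain or a carboxylic acid would read at this position also stays open.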